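Replacing Acetyl with Methoxy in Compound 2

The source may hold more compounds than are shown below. What is called first, only, known or untested is meant among the compounds shown, and "the series" means these compounds.

Compound 1 `Cc1ccc(N/N=C2\CCCc3ccccc3C2=O)cc1`: 56300 nM
Compound 2 `CC(=O)c1ccc(N/N=C2\CCCc3ccccc3C2=O)cc1`: 56100 nM

In a functional assay for inhibition, read by HPLC (a higher number here means a weaker inhibitor, a lower number a stronger inhibitor), compound 2 gives 56100 nM, which lies within the scatter of compound 1. Compound 3 `COc1ccc(N/N=C2\CCCc3ccccc3C2=O)cc1` carries methoxy in place of acetyl on an aromatic carbon, para to a large group (methoxy in place of acetyl on an aromatic carbon). Going by the values given here, one measured step bears on this change, a swap at an aromatic carbon: a 1.0-fold lower number from compound 1 to compound 2 (0.00 log units; within the scatter). Among the compounds with values here, with only that step, which stayed within the scatter, no change beyond the scatter is expected. The estimated step is a 1.1-fold lower number from compound 2 to compound 3 (0.05 log units; within the scatter). Compound 3 is expected at about 50000 nM, with an estimated range of 20000 nM to 120000 nM.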

Compound 3, half-maximal inhibitory concentration: 54200 nM
The estimate for compound 3 lay 1.1-fold (0.04 log units) below the measured number; the measured number falls inside the stated range.
By their numbers in this assay, from the lowest: compounds 3, 2 and 1 (each within the scatter of the next).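

In this assay, methoxy on this aromatic carbon, para to a large group, stays within the scatter of both earlier groups, with a 1.0-fold lower number from compound 2 to compound 3 (0.01 log units; within the scatter) and a 1.0-fold lower number from compound 1 to compound 3 (0.02 log units; within the scatter). Methyl, acetyl and methoxy therefore cannot be told apart at this place, and the earlier pair alone could not show that this held for a third group. Nothing available explains this flat result. The compounds shown leave open whether an amine, a carboxylic acid or a longer chain here would move the number beyond the scatter. They also leave open whether any other place on this ring would respond differently.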